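This account rests on a few compounds, and the source may have more. Where it says the series, first, only, none or still open, it means among the compounds named here.

Measured compounds:
compound 1 `CC(C)(N)C(=O)N[C@H](COCc1cc(Cl)cc(Cl)c1)c1nnnn1CCOC(=O)NCCCCO` — 6.75 nM
compound 2 `CC(C)(N)C(=O)N[C@H](COCc1cccc(C(F)(F)F)c1)c1nnnn1CCOC(=O)NCCCCO` — 1.79 nM
compound 3 `Cc1ccccc1COC[C@@H](NC(=O)C(C)(C)N)c1nnnn1CCOC(=O)NCCCCO` — 0.51 nM

All three numbers come from a functional assay on cells for inhibition of growth hormone secretagogue receptor type 1 (Homo sapiens), read by FLIPR and calcium flux; a lower number here means that less compound is needed, a higher number that more compound is needed for the effect. Compound 2 stands second highest of the three; its nearest neighbour is reached by a 3.5-fold lower number from compound 2 to compound 3 (0.55 log units; beyond the scatter) and its furthest by a 3.8-fold lower number from compound 1 to compound 2 (0.58 log units; beyond the scatter). Compound 4 `CC(C)(N)C(=O)N[C@H](COCc1ccccc1-c1ccccc1)c1nnnn1CCOC(=O)NCCCCO` is not yet measured. The change from compound 2 is 2-phenylphenyl in place of 3-(trifluoromethyl)phenyl on a saturated chain carbon bound to an oxygen on a saturated carbon. Every measured step alters the same aryl group at this place, each giving a lower number: a 3.8-fold lower number from compound 1 to compound 2 (0.58 log units; beyond the scatter), a 3.5-fold lower number from compound 2 to compound 3 (0.55 log units; beyond the scatter) and a 13-fold lower number from compound 1 to compound 3 (1.12 log units; beyond the scatter). The 2-methylphenyl of compound 3 gave the lowest number, and 2-phenylphenyl is named in parallel, so a modest step down or one within the scatter is expected, a 1.8-fold lower number from compound 2 to compound 4 (0.25 log units; within the scatter). Compound 4 is estimated at 1 nM, range 0.3 nM to 3.5 nM.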

Compound 4, half-maximal effective concentration: 0.34 nM
Compound 4: middle estimate off by 2.9-fold (0.47 log units), on the high side; the measured number falls inside the stated range.
By their numbers in this assay, from the lowest: compounds 4 and 3 (each within the scatter of the next); then compound 2; then compound 1.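

In this assay, a second aromatic ring is accepted on the saturated chain carbon bound to an oxygen: 2-phenylphenyl gives a 5.3-fold lower number from compound 2 to compound 4 (0.72 log units; beyond the scatter) and a 20-fold lower number from compound 1 to compound 4 (1.30 log units; beyond the scatter). Phenyl in place of methyl on an aromatic carbon gives a 1.5-fold lower number from compound 3 to compound 4 (0.18 log units; within the scatter), so the outer ring neither gains nor loses measurably against the methyl. Among these four compounds, 2-methylphenyl and 2-phenylphenyl both stand below 3-(trifluoromethyl)phenyl and 3,5-dichlorophenyl, with no compound against this pattern.

No supporting data explain these differences. From the compounds shown here alone, whether an amine or a carboxylic acid on the outer phenyl would hold this low number remains open.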